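Taking the acetyl off compound 2: a cytotoxicity estimate

The compounds below may be only part of what the source reports. "The series", "measured", "known", "first", "only" and "open" are said of these compounds alone.

Values in an ADME assay on MT4 cells (Homo sapiens) for cytotoxicity, read by MTT assay, with a stated time of 4 days; a higher number here means that more compound is tolerated, a lower number that less compound is tolerated
- compound 1 `COc1ccc(-c2oc3ccc(NC(C)=O)cc3c(=O)c2O)cc1` gives 98700 nM
- compound 2 `COc1ccc(-c2oc3ccc(NC(C)=O)cc3c(=O)c2OC)cc1` gives 369000 nM
- compound 3 `COc1c(-c2cccc(F)c2)oc2ccc(NC(C)=O)cc2c1=O` gives 210000 nM

Compound 2 shares the top of this small range with one neighbour, as the comparison shows a 1.8-fold lower number from compound 2 to compound 3 (0.24 log units; within the scatter). Its other neighbour sits clearly lower, with a 3.7-fold higher number from compound 1 to compound 2 (0.57 log units; beyond the scatter). Compound 4 `COc1ccc(-c2oc3ccc(N)cc3c(=O)c2OC)cc1` is compound 2 with hydrogen in place of acetyl on a nitrogen on an aromatic ring, so acetamido becomes amino (hydrogen in place of acetyl on a nitrogen on an aromatic ring).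

Among the compounds with values here, all three measured compounds keep the acetamido group, so no measured step shows this change directly. The two steps above were made elsewhere on the molecule and serve only as a guide to size, and they suggest a modest step. Compound 2 already stands at 369000 nM, near the top of the range, so a lower number seems the likelier direction, though this is weakly supported.

The expected step is a 2.2-fold lower number from compound 2 to compound 4 (0.34 log units; beyond the scatter).

For compound 4 the estimated value is 170000 nM, with an expected range from 60000 nM to 450000 nM.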

Compound 4, half-maximal cytotoxic concentration: 200000 nM
Beside the measured number, compound 4's estimate is 1.2-fold (0.07 log units) below it; the range from low to high includes it.
By their numbers in this assay, from the lowest: compound 1; then compounds 4, 3 and 2 (each within the scatter of the next).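

In this assay, within the data shown here, this pair gives the first direct look at the acetamido group, which all the earlier compounds carry: hydrogen in place of acetyl on the nitrogen gives a 1.8-fold lower number from compound 2 to compound 4 (0.27 log units; within the scatter). For this pair, then, amino can stand in for acetamido without a difference that rises above the spread of repeat measurements. Nothing available here explains this outcome.

Only compound 2 has an amino partner among these compounds, so it remains open whether the same change would behave alike with the 3-fluorophenyl group of compound 3 or the oxygen-bound hydrogen of compound 1. Also open, going by these compounds, is how the number would respond to a different group on that nitrogen, such as a propanoyl or methanesulfonyl group, or to a carboxylic acid in place of the acetamido group.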